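The compounds below may be only part of what the source reports. "The series", "measured", "known", "first", "only" and "open" are said of these compounds alone.

Measured compounds:
compound 1, `COc1cc(-c2cc(/C=C/C(=O)c3ccc(Cl)c(Cl)c3)[nH]n2)cc(OC)c1OC`, 96%
compound 2, `COc1ccc(-c2cc(/C=C/C(=O)c3cc(OC)c(OC)c(OC)c3)[nH]n2)cc1OC`, 68%

In a functional assay on HT-29 cells (Homo sapiens) for cytotoxicity, read by sulforhodamine B assay, with a stated time of 48 h, tested at 1 uM (on this read-out higher numbers stand for a weaker effect at the one concentration tested and lower numbers for a stronger effect), compound 1 gives 96%, the highest of the two numbers, so it shows the weaker effect at the single concentration tested. Going by the values given here, compound 2 gives 68%, a number that lies beyond the usual scatter from compound 1; no single-change step between these two is known, so their two values are all that can be said.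

Compound 3, `COc1ccc(C(=O)/C=C/c2cc(-c3cc(OC)c(OC)c(OC)c3)n[nH]2)cc1OC`, has not been measured. It differs from compound 1 in one place: 3,4-dimethoxyphenyl in place of 3,4-dichlorophenyl on a carbonyl carbon. Among the compounds with values here, with no step between measured compounds to lean on, a modest move toward a stronger effect in this assay is expected, but it may well stay within the scatter. The step from compound 1 to compound 3 is estimated at a number 16 percentage points lower from compound 1 to compound 3 (beyond the scatter). Compound 3 is expected to give about 80%, between 55% and 100%.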

Compound 3, a percentage reported as activity, at one concentration (the size of the read-out at that concentration, not a potency): 88%
The estimate for compound 3 lay 8 percentage points below the measured number; measured number inside the range.
By their numbers in this assay, from the lowest: compound 2; then compounds 3 and 1 (each within the scatter of the next).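

In this assay, going by these compounds alone, putting 3,4-dimethoxyphenyl in place of 3,4-dichlorophenyl on a carbonyl carbon gives the first single-change comparison in this set, a step of a number 8 percentage points lower from compound 1 to compound 3 (within the scatter) and therefore too small to count as a real difference. At this position, then, a ring carrying two chlorine atoms and a ring carrying two methoxy groups cannot be told apart at the one concentration tested, even though the entering group is larger and adds hydrogen-bond acceptors. No measurement at hand accounts for this result.

On these data alone, what an amine or a carboxylic acid would do in place of these rings on the carbonyl carbon stays open. So does whether a ring bearing a fluorine atom or a longer chain such as butoxy would read the same.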